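The source may hold more compounds than are shown below. What is called first, only, known or untested is meant among the compounds shown, and "the series" means these compounds.

Measured so far, all in an ADME assay on HPLF cells (Homo sapiens) for cytotoxicity, with a stated time of 48 h; on this read-out higher numbers stand for lower toxicity in this test and lower numbers for higher toxicity in this test:
compound 1 `COc1ccc(/C=C/C(=O)c2c(C)[n+]([O-])c3ccccc3[n+]2[O-])cc1`: 93000 nM
compound 2 `COc1ccc(/C=C/C(=O)c2c(C)[n+]([O-])c3ccccc3[n+]2[O-])cc1OC`: 156000 nM
compound 3 `Cc1c(C(=O)/C=C/c2ccc(Cl)cc2)[n+]([O-])c2ccccc2[n+]1[O-]`: 12000 nM

Compound 3 gives the lowest number of the three in this assay: compound 1 sits a 7.8-fold lower number from compound 1 to compound 3 (0.89 log units; beyond the scatter) away, and compound 2 is further still. The step from compound 1 to compound 2 (a 1.7-fold higher number from compound 1 to compound 2 (0.22 log units; within the scatter)) lies within the scatter, so those two values cannot be ordered.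

Compound 4 `Cc1c(C(=O)/C=C/c2ccc(Cl)c(Cl)c2)[n+]([O-])c2ccccc2[n+]1[O-]` differs from compound 3 by chloro in place of hydrogen on an aromatic carbon. Going by the values given here, of the measured steps, only the one from compound 1 to compound 2 puts an added group on the same aromatic ring, and it moved the number by a 1.7-fold higher number from compound 1 to compound 2 (0.22 log units; within the scatter), within the scatter. The step from compound 1 to compound 3 exchanged groups rather than adding one and is less comparable. Among the compounds with values here, no measured step adds a second chloro group.

Compound 4 is therefore expected to stay close to compound 3, with a 1.5-fold lower number from compound 3 to compound 4 (0.18 log units; within the scatter) as the estimated shift, giving an expected value of 8000 nM in this assay, in the range 3000 nM to 25000 nM.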

Compound 4, half-maximal cytotoxic concentration: 5700 nM
Estimate against measurement, compound 4: 1.4-fold (0.15 log units) above; measured number inside the range.
By their numbers in this assay, from the lowest: compound 4; then compound 3; then compounds 1 and 2 (each within the scatter of the next).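

In this assay, adding a chloro group to the 4-chlorophenyl ring, ortho to a chloro group and meta to a large group, gives a 2.1-fold lower number from compound 3 to compound 4 (0.32 log units; beyond the scatter) and so moves the number beyond the scatter. Going by these compounds alone, the only other added group on this ring, a methoxy, gave a 1.7-fold higher number from compound 1 to compound 2 (0.22 log units; within the scatter) and stayed within it. Taken together, the change from 4-methoxyphenyl to 3,4-dichlorophenyl gives a 16-fold lower number from compound 1 to compound 4 (1.21 log units; beyond the scatter) and marks a clear rise in toxicity in this test, while nothing measured here bears on what lies behind either step.

Open, as far as these compounds go, is whether a bromo, a trifluoromethyl or an amine at the same place would lower the number as chloro does. Also open, from the compounds shown here alone, is what a chloro group at this place gives without the 4-chloro group.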